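A few compounds are considered here, and "the series" means these few. Any claim that something is new, unique, unknown or untested is made for them only; others in the source may bear on it.

Measured so far in an ADME assay on the whole organism with Oryza sativa as the target, tested at 1 uM; on this read-out lower numbers stand for a stronger effect and higher numbers for a weaker effect at the one concentration tested:
- compound 1 `Cc1ccccc1NC(=O)N[C@H](C)c1ccccc1` gives 100%
- compound 2 `Cc1ccccc1NC(=O)N[C@@H](C)c1ccccc1` gives 99%
- compound 3 `C[C@H](NC(=O)Nc1ccccc1F)c1ccccc1` gives 92%

On these numbers compound 1 sits in one band with the other two: the step of a number 1 percentage points lower from compound 1 to compound 2 (within the scatter) is within the scatter, as fits (the fact that compounds 1 and 2 differ only in the configuration as drawn), and the step of a number 7 percentage points lower from compound 2 to compound 3 (within the scatter) is within the scatter as well. Compound 4 `C[C@@H](NC(=O)Nc1ccccc1Br)c1ccccc1` differs from compound 1 in this way: bromo in place of methyl on an aromatic carbon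

The step from compound 2 to compound 3 bears most directly on this change, since it also swaps the methyl on that aromatic carbon for a halogen, and it stayed within the scatter. A step of the same small size is therefore expected for compound 4 in this assay, as a number 7 percentage points lower from compound 1 to compound 4 (within the scatter). Compound 4 is thus estimated at 93%, with a range from 80% to 100%.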

Compound 4, a percentage reported as activity, at one concentration (the size of the read-out at that concentration, not a potency): 100%
Compound 4: middle estimate off by 7 percentage points, on the low side, and the stated range covers the measured number.
By their numbers in this assay, from the lowest: compounds 3, 2, 1 and 4 (each within the scatter of the next).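

In this assay, bromo in place of methyl on this aromatic carbon, ortho to a large group, gives no change at the digits printed from compound 1 to compound 4 (within the scatter) in the read-out. Together with the fluoro of compound 3, this means that two different halogens have now stood at this position without a step beyond the scatter. Nothing known here explains this result.

From the compounds shown here alone, it remains open whether an amine, a carboxylic acid or a longer chain at this position would give a step beyond the scatter. Going by these compounds, whether any such step would appear at other concentrations also remains open.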